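Compound 4: a side-group swap at the assay limit

The compounds below may be only part of what the source reports. "The series", "measured", "known", "first", "only" and "open" are said of these compounds alone.

Compound 1 `C[C@H]1O[C@]1(C)C(=O)C[C@@H]1[C@@]2(C)[C@@H](O)CCC(C)(C)[C@]2(O)CC[C@@]1(C)O`: > 10000 nM
Compound 2 `C[C@H]1O[C@]1(C)C(=O)C[C@H]1[C@](C)(O)CC[C@@]2(O)C(C)(C)CCC[C@]12C`: > 10000 nM
Compound 3 `C/C=C(\C)C(=O)C[C@]1(O)[C@@]2(C)CCCC(C)(C)[C@]2(O)CC[C@@]1(C)O`: > 10000 nM

In a functional assay on A549 cells (Homo sapiens) for cytotoxicity, read by MTT assay, with a stated time of 24 h (a lower number here means a stronger inhibitor, a higher number a weaker inhibitor), compound 1 gives > 10000 nM, which is a limit and not a number. Compound 1 therefore has no exact place on the scale, and the same holds across the set, with the limit of > 10000 nM in this assay, at which 3 of the 3 values shown sit.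

Compound 4 `C/C=C(\C)C(=O)C[C@@H]1[C@@]2(C)[C@@H](O)CCC(C)(C)[C@]2(O)CC[C@@]1(C)O` has not yet been measured. It differs from compound 1 at one place: on a carbonyl carbon, 1-methylprop-1-en-1-yl stands in place of 2,3-dimethyloxiran-2-yl (1-methylprop-1-en-1-yl in place of 2,3-dimethyloxiran-2-yl on a carbonyl carbon). The three-membered ring goes and a double bond enters.

Within the data shown here, the only measured step, a step that the two limits leave unreadable from compound 1 to compound 2, is a different change, hydrogen in place of hydroxy on a saturated ring carbon, and its size cannot be read. Closer to the case is compound 3, which carries the same 1-methylprop-1-en-1-yl on its carbonyl carbon. Compound 3 gives > 10000 nM, again a limit.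

Nothing measured points to a gain in strength, so no step beyond the scatter is expected, and the most likely result is another limit. The expected size of the change is a step that the limit leaves unreadable from compound 1 to compound 4. For compound 4 the estimated value is 20000 nM. The expected range for compound 4 runs from 8000 nM to 50000 nM.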

Compound 4, half-maximal inhibitory concentration: > 10000 nM
Compound 4: no number, only a limit (the forecaster's own chance of this, stated with the estimate: 85%); the middle value lies beyond the limit too.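

Among these compounds, compound 4, like compound 1, gives only a limit in this assay, so no step between compound 1 and compound 4 can be read. The compounds shown leave open how strong any of them truly is, and whether swapping 2,3-dimethyloxiran-2-yl for 1-methylprop-1-en-1-yl changes that strength at all, since all of them stop at one point: the limit of > 10000 nM in this assay, at which 4 of the 4 values shown sit.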